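The compounds below may be only part of what the source reports. "The series", "measured", "known", "first", "only" and "open" are said of these compounds alone.

Compound 1 `Cn1cnc2c(Sc3ccc(F)cc3)ncnc21`: 5%
Compound 2 `Clc1ncnc2ncn(Cc3ccccc3)c12`: 0%
Compound 3 `Fc1ccc(Cn2cnc3c(Cl)ncnc32)cc1`: 0%

In an assay on isolated protein for inhibition of Ca2+/calmodulin-dependent protein kinase II (CaM kinase II) (Rattus norvegicus), tested at 30 uM (a higher number here means more inhibition at the concentration tested (going by the name of the read-out), a lower number less inhibition), compound 2 gives 0%, level with compound 3 at the precision reported and together with it the lowest of the three numbers. The furthest of the three is compound 1, which gives 5%, a number still within the scatter of compound 2. All three measured numbers therefore sit within the scatter of one another.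

Compound 4 `Fc1ccc(Cn2cnc3ncnc(Cl)c32)cc1` has not been measured. It differs from compound 2 by fluoro in place of hydrogen on an aromatic carbon. Within the data shown here, no step between measured compounds carries this change, so nothing shows its effect. The step from compound 2 to compound 4 is expected to be a number 2 percentage points higher from compound 2 to compound 4 (within the scatter), that is, none beyond the scatter. Compound 4 is estimated at 2%, with a range from 0% to 12%.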

Compound 4, a percentage reported as inhibition, at one concentration (the size of the read-out at that concentration, not a potency): 8%
Compound 4: the middle estimate sits 6 percentage points below what was measured; measured number inside the range.
By their numbers in this assay, from the lowest: compounds 2, 3, 1 and 4 (each within the scatter of the next).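

In this assay, among these compounds, fluoro in place of hydrogen on an aromatic carbon, para to a large group, gives a number 8 percentage points higher from compound 2 to compound 4 (within the scatter) and this is the first readable step at this position. The ring carbon therefore takes a fluoro group with no change beyond the scatter, so this single substitution gives no sign of a trend. Nothing measured bears on the step, and no reason for it can be given.

Still open, on these data alone, is whether an amine, a methoxy group or a carboxylic acid at this place would move the number beyond the scatter.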